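The source may hold more compounds than are shown below. What is called first, only, known or untested is meant among the compounds shown, and "the series" means these compounds.

Compound 1 (`Brc1ccc(CSc2nnc(-c3cnccn3)o2)cc1`) gives 25700 nM in a functional assay on BGC-823 cells (Homo sapiens) for antiproliferative activity, read by MTT assay, with a stated time of 48 h (on this read-out higher numbers stand for weaker inhibition and lower numbers for stronger inhibition), and compound 2 (`Clc1ccccc1CSc1nnc(-c2cnccn2)n1-c1ccccc1`) gives 34700 nM there, so compound 2 stands within the scatter of compound 1. Compound 3 (`Fc1cccc(F)c1CSc1nnc(-c2cnccn2)n1-c1ccccc1`) carries 2,6-difluorophenyl in place of 2-chlorophenyl on a saturated chain carbon bound to a sulfur. Going by the values given here, no measured pair yet isolates a single change, so the data offer no direct guide. The expected step (a 1.2-fold lower number from compound 2 to compound 3 (0.09 log units; within the scatter)) in this assay stays within the scatter. For compound 3 the estimated value is 28000 nM and is expected to fall between 11000 nM and 60000 nM.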

Compound 3, half-maximal inhibitory concentration: > 50000 nM
Compound 3 ended at the assay's limit; the forecaster's own chance of this, stated with the estimate: 8%; middle value at least 1.7-fold (0.25 log units) from the limit.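

In this assay compound 3 reads as a limit and not as a number: the limit of > 50000 nM in this assay, at which 1 of the 3 values shown sits. This is the first single change shown at this position, on a saturated chain carbon bound to a sulfur: 2,6-difluorophenyl in place of 2-chlorophenyl brings an at least 1.4-fold higher number from compound 2 to compound 3 (0.15 log units; that floor lies within the scatter) and so shows no stronger inhibition, while the full size of the step stays unknown. The compounds shown leave open whether an amine or a carboxylic acid on the phenyl ring, or a longer chain in place of the benzyl, would lower the number.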